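The source may report more compounds than this note shows. Statements on the series, on what has been measured and on what is new or still open speak of the compounds shown alone.

Compound 1 `COc1cc(C(=O)c2sc(-c3ccc([N+](=O)[O-])cc3)cc2N)cc(OC)c1OC`: 100 nM
Compound 2 `COc1cc(C(=O)c2sc(-c3ccccc3Cl)cc2N)cc(OC)c1OC`: 20 nM
Compound 3 `COc1cccc(-c2cc(N)c(C(=O)c3cc(OC)c(OC)c(OC)c3)s2)c1`: 22 nM

These values come from a functional assay on L1210 cells (Mus musculus) for antiproliferative activity; a lower number here means a stronger inhibitor, a higher number a weaker inhibitor. Compound 3, at 22 nM, cannot be told apart from compound 2, while compound 1 has a clearly higher number.

Compound 4 `COc1cc(C(=O)c2sc(-c3ccc(C)cc3)cc2N)cc(OC)c1OC` differs from compound 3 in one place: 4-methylphenyl in place of 3-methoxyphenyl on an aromatic carbon. This puts 4-methylphenyl in place of 3-methoxyphenyl on an aromatic carbon.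

Two measured steps at this same place bear on the change. Exchanging 2-chlorophenyl for 3-methoxyphenyl gave a 1.1-fold higher number from compound 2 to compound 3 (0.04 log units; within the scatter), while leaving 4-nitrophenyl gave a 4.5-fold lower number from compound 1 to compound 3 (0.66 log units; beyond the scatter). Three compounds set no firm rule, and 4-methylphenyl has not been measured, so no step beyond the scatter is expected, though a modest rise remains possible.

The expected step is a 1.4-fold higher number from compound 3 to compound 4 (0.13 log units; within the scatter).

Compound 4 is estimated at 30 nM, within an expected range of 10 nM to 90 nM.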

Compound 4, half-maximal inhibitory concentration: 18 nM
Compound 4: the middle estimate sits 1.7-fold (0.22 log units) above what was measured; measured number inside the range.
By their numbers in this assay, from the lowest: compounds 4, 2 and 3 (each within the scatter of the next); then compound 1.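

In this assay, 4-methylphenyl cannot be told apart from either 3-methoxyphenyl (a 1.2-fold lower number from compound 3 to compound 4 (0.09 log units; within the scatter)) or 2-chlorophenyl (a 1.1-fold lower number from compound 2 to compound 4 (0.05 log units; within the scatter)), so this position now holds three different phenyl groups with matching numbers, one of them with no hydrogen-bond acceptor. Only the 4-nitrophenyl group stands apart, and swapping its nitro for methyl gives a clear step (a 5.6-fold lower number from compound 1 to compound 4 (0.74 log units; beyond the scatter)). Nothing given here explains that gap.

Still open, on these data alone, is whether an amine, a carboxylic acid or a longer chain at the 4-position of this phenyl group would match methyl or nitro.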